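The compounds below may be only part of what the source reports. "The series", "measured", "known", "first", "only" and "open" are said of these compounds alone.

Three compounds share one fused core and differ only in the two aromatic groups attached to it. Compound 2 `COc1cc(-c2ccnc3cc(-c4ccc5cc[nH]c5c4)nn23)cc(OC)c1OC` stands best among them: in a functional assay on A549 cells (Homo sapiens) for inhibition, read by CCK-8 assay, with a stated time of 48 h (on this read-out lower numbers stand for stronger inhibition and higher numbers for weaker inhibition), compound 2 gives 170 nM, the lowest of the two numbers recorded. Compound 1 `Cn1ccc2cc(-c3cc4nccc(-c5ccc(F)cc5)n4n3)ccc21` gives in this assay 3520 nM, a number that sits beyond the usual scatter above compound 2. Compound 3 `Cc1ccc(-c2cc3nccc(-c4ccc(F)cc4)n3n2)cc1` reaches only a limit in this assay, > 10000 nM; (the limit of > 10000 nM in this assay, at which 1 of the 3 values shown sits). Compound 4 `COc1cc(-c2ccnc3cc(-c4ccc(C(C)(C)C)cc4)nn23)cc(OC)c1OC` has not yet been measured. It is made from compound 2 by a single change: 4-(tert-butyl)phenyl in place of 1H-indol-6-yl on an aromatic carbon. Among the measured compounds shown here, no measured pair differs in exactly this way, so the size of the step cannot be read off directly; the two weaker compounds both carry a plain six-membered ring in place of the groups found in compound 2, which hints that simplifying an aromatic group costs activity. The step from compound 2 to compound 4 is therefore expected to be a loss, an 8.8-fold higher number from compound 2 to compound 4 (0.95 log units; beyond the scatter), beyond the scatter. Compound 4 is estimated at 1500 nM, with a likely range from 300 nM to 8000 nM.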

Compound 4, half-maximal inhibitory concentration: > 10000 nM
Compound 4: no number, only a limit; the forecaster's own chance of this, stated with the estimate: 10%; middle value at least 6.6-fold (0.82 log units) from the limit.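

In this assay, among the compounds shown here, placing 4-(tert-butyl)phenyl in place of 1H-indol-6-yl on this aromatic carbon gives an at least 58-fold higher number from compound 2 to compound 4 (1.76 log units; beyond the scatter), the first step that can be read at a single place. Everything else in compound 2 stays the same, so the rest of the molecule does not hold the activity on its own once this group is exchanged. The value of compound 4 is a limit and not a number, so the step gives only the smallest possible size of the loss: the limit of > 10000 nM in this assay, at which 2 of the 4 values shown sit.

The compounds shown leave open whether the loss comes from removing the indole's five-membered ring with its hydrogen-bond donor or from adding the tert-butyl group, as both happen in this one change. As far as these compounds go, whether a plain phenyl or a 4-aminophenyl group at this place would keep any activity also remains open.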